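Methyl placement on a shared core: expected step for compound 4

The source may report more compounds than this note shows. Statements on the series, on what has been measured and on what is new or still open speak of the compounds shown alone.

Compound 1 `O=c1ccc2cc(Oc3ccc(Cl)cc3O)ccc2o1` gives 96200 nM in an ADME assay on L6 cells (Rattus norvegicus) for inhibition, read by fluorescence, with a stated time of 72 h; a higher number here means a weaker inhibitor, a lower number a stronger inhibitor. Compound 2 `Cc1cc(=O)oc2ccc(Oc3ccc(Cl)cc3O)cc12` gives 35500 nM in this assay; the difference is methyl in place of hydrogen on an aromatic carbon, and the step is a 2.7-fold lower number from compound 1 to compound 2 (0.43 log units; beyond the scatter). Compound 3 `O=c1oc2ccccc2cc1Oc1ccc(Cl)cc1O` gives 108000 nM in this assay; it has the same atoms as compound 1 joined differently, and the difference between the two cores is not broken down here. Compound 4 `Cc1c(Oc2ccc(Cl)cc2O)c(=O)oc2ccccc12` is not yet measured and differs from compound 3 by methyl in place of hydrogen on an aromatic carbon. This is the same kind of change as that from compound 1 to compound 2, but not the same: in compound 4 the methyl is also ortho to a group of 9 heavy atoms. The expected step of a 2.3-fold lower number from compound 3 to compound 4 (0.35 log units; beyond the scatter) is set a little smaller than the precedent because a 2.7-fold lower number from compound 1 to compound 2 (0.43 log units; beyond the scatter) was measured with different surroundings. Compound 4 is estimated at 48000 nM in this assay, within 16000 nM to 140000 nM.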

Compound 4, half-maximal inhibitory concentration: 51500 nM
Estimate against measurement, compound 4: 1.1-fold (0.03 log units) below; the range from low to high includes it.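

In this assay methyl in place of hydrogen on an aromatic carbon gives a 2.1-fold lower number from compound 3 to compound 4 (0.32 log units; beyond the scatter) and so lowers the number on the core of compound 3 as well as on the core of compound 1, with no difference in step size that can be told apart: the same change on two cores in this assay, a 2.7-fold lower number (0.43 log units; beyond the scatter) from compound 1 to compound 2 and a 2.1-fold lower number (0.32 log units; beyond the scatter) from compound 3 to compound 4, 1.3-fold (0.11 log units) apart, within the scatter of two such steps. This holds with the methyl of compound 4 ortho to a group of 9 heavy atoms. The agreement rests on two pairs only and shows neither why the number falls nor how the change behaves on any other core.

From the compounds shown here alone, whether ethyl, a longer chain, an amine or a carboxylic acid in the same place would lower the number on both cores remains open. Going by these compounds, whether the methyl step holds in other assays is also open.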